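The source may report more compounds than this note shows. Statements on the series, on what has been measured and on what is new or still open speak of the compounds shown alone.

Measured in a functional assay on MCF7 cells (Homo sapiens) for inhibition, read by MTT assay, with a stated time of 72 h; a lower number here means a stronger inhibitor, a higher number a weaker inhibitor:
compound 1, `Fc1ccc(-c2nnc(SCCCN3CCN(c4nc5ccccc5o4)CC3)o2)cc1`, 52300 nM
compound 2, `Oc1ccc(-c2nnc(SCCCN3CCN(c4nc5ccccc5o4)CC3)o2)cc1`, 260000 nM
compound 3, `c1ccc(-c2nnc(SCCCN3CCN(c4nc5ccccc5o4)CC3)o2)cc1`, 117000 nM

Compound 1 holds the lowest number of the three. Its nearest neighbour is compound 3, at a 2.2-fold higher number from compound 1 to compound 3 (0.35 log units; beyond the scatter); the furthest is compound 2, at a 5.0-fold higher number from compound 1 to compound 2 (0.70 log units; beyond the scatter). Both steps, and a 2.2-fold lower number from compound 2 to compound 3 (0.35 log units; beyond the scatter), change only the group on the aromatic carbon.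

Compound 4, `Fc1ccc(-c2nnc(SCCCN3CCN(c4nc5ccccc5s4)CC3)o2)cc1`, differs from compound 1 by 1,3-benzothiazol-2-yl in place of 1,3-benzoxazol-2-yl on an amine nitrogen in a ring. Among the compounds with values here, no measured step concerns this part of the molecule, so none bears directly on the change. With the fluoro retained, compound 4 is expected to stay close to compound 1; the step of a 1.2-fold lower number from compound 1 to compound 4 (0.07 log units; within the scatter) is estimated to lie within or near the scatter. In this assay compound 4 is expected to give 45000 nM, in the range 15000 nM to 150000 nM.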

Compound 4, half-maximal inhibitory concentration: 84100 nM
Compound 4: middle estimate off by 1.9-fold (0.27 log units), on the low side; the range from low to high includes it.
By their numbers in this assay, from the lowest: compounds 1, 4 and 3 (each within the scatter of the next, the first and the last beyond it); then compound 2.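

In this assay the change on the amine nitrogen in a ring gives a 1.6-fold higher number from compound 1 to compound 4 (0.21 log units; within the scatter) and so does not separate 1,3-benzothiazol-2-yl from 1,3-benzoxazol-2-yl when the fluoro is retained. This position therefore tolerates sulfur in place of oxygen in this group, whereas all three steps on the aromatic carbon lie beyond the scatter. No evidence on the cause of this result is at hand.

Still open, from the compounds shown here alone, is whether 1,3-benzothiazol-2-yl gives the same picture with hydrogen or hydroxy on the aromatic carbon. Also open, going by these compounds, is how a phenyl or an acetyl on the same ring nitrogen would compare.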